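A Dichlorophenyl Thioether Variant of Compound 2

The compounds below may be only part of what the source reports. "The series", "measured", "known", "first", "only" and "open" are said of these compounds alone.

Compound 2 `Nc1cc(N)c2nc(-c3ccccc3)c(Sc3ccc(F)cc3)nc2c1` carries a (4-fluorophenyl)sulfanyl group on the shared core. In a functional assay on MCF7 cells (Homo sapiens) for inhibition, read by sulforhodamine B assay, with a stated time of 48 h (on this read-out lower numbers stand for stronger inhibition of growth and higher numbers for weaker inhibition of growth), compound 2 gives 63100 nM, the highest of the two numbers reported so far; compound 1 `Nc1cc(N)c2nc(-c3ccccc3)c(NCc3ccc(Cl)c(Cl)c3)nc2c1` gives 53700 nM in this assay, and the gap between them lies within the usual scatter. Compound 3 `COc1cc(CNc2nc3cc(N)cc(N)c3nc2-c2ccccc2)cc(OC)c1OC` is reported only at the limit of < 50200 nM in this assay, at which 1 of the 3 values shown sits, recorded as < 50200 nM. Compound 4 `Nc1cc(N)c2nc(-c3ccccc3)c(Sc3ccc(Cl)c(Cl)c3)nc2c1` is compound 2 with 3,4-dichlorophenyl in place of 4-fluorophenyl on a sulfur. Because compound 1, which gives 53700 nM, also carries a 3,4-dichlorophenyl group and sits close to compound 2, the expected step of a 1.4-fold lower number from compound 2 to compound 4 (0.15 log units; within the scatter) is small, toward a slightly lower number, not clearly beyond the scatter. Compound 4 is therefore estimated at 45000 nM, within 15000 nM to 100000 nM.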

Compound 4, concentration for total growth inhibition: 38000 nM
Compound 4: middle estimate off by 1.2-fold (0.07 log units), on the high side, and the stated range covers the measured number.
By their numbers in this assay, from the lowest: compounds 4, 1 and 2 (each within the scatter of the next).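

In this assay, among these compounds, putting 3,4-dichlorophenyl in place of 4-fluorophenyl on a sulfur gives a 1.7-fold lower number from compound 2 to compound 4 (0.22 log units; within the scatter) and this is the first step that can be read between two compounds differing in one place. The aromatic ring on this sulfur can carry two chlorines instead of one fluorine without a shift beyond the scatter.

From the compounds shown here alone, whether an amine, a carboxylic acid or a longer chain in place of this ring would move the number beyond the scatter stays open. Nothing shown bears on why this step has its size.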